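Swapping Fluoro for Trifluoromethyl on a Phenoxy Ring

The source may hold more compounds than are shown below. What is called first, only, known or untested is meant among the compounds shown, and "the series" means these compounds.

Compound 1 `O=C(O)c1csc([C@H]2CC[C@@H]3[C@@H](/C=C/[C@@H](O)COc4ccccc4)[C@H](O)C[C@@H]3O2)n1` gives 7.9 nM in a functional assay on CHO cells for agonist activity at prostaglandin E2 receptor EP2 subtype (Homo sapiens), read by HTRF and cAMP accumulation, with a stated time of 30 min; a higher number here means that more compound is needed for the effect, a lower number that less compound is needed.
Compound 2 `O=C(O)c1csc([C@H]2CC[C@@H]3[C@@H](COc4ccccc4F)[C@H](O)C[C@@H]3O2)n1` gives 23 nM.
Compound 3 `O=C(O)c1csc([C@H]2CC[C@@H]3[C@@H](/C=C/CCOc4ccccc4)[C@H](O)C[C@@H]3O2)n1` gives 3.9 nM.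

Among these three, compound 2 stands highest, with compound 1 nearer to it and compound 3 furthest, both lower. For the measured compounds named here, the only measured step, a 2.0-fold lower number from compound 1 to compound 3 (0.31 log units; beyond the scatter), alters the side chain rather than the aromatic ring, so no measured step bears directly on the change now considered. Compound 4 `O=C(O)c1csc([C@H]2CC[C@@H]3[C@@H](COc4ccccc4C(F)(F)F)[C@H](O)C[C@@H]3O2)n1` differs from compound 2 in one place: trifluoromethyl in place of fluoro on an aromatic carbon. With nothing in the measured set to guide the direction, the expectation is a step no larger than the scatter, a 1.3-fold higher number from compound 2 to compound 4 (0.12 log units; within the scatter). Compound 4 is therefore estimated at 30 nM, with a range from 10 nM to 90 nM.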

Compound 4, half-maximal effective concentration: 0.5 nM
The estimate for compound 4 lay 60-fold (1.78 log units) above the measured number; the whole stated range lies above it.
By their numbers in this assay, from the lowest: compound 4; then compound 3; then compound 1; then compound 2.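

At this aromatic carbon, ortho to a large group, the choice of substituent matters greatly: in this assay, trifluoromethyl in place of fluoro gives a 46-fold lower number from compound 2 to compound 4 (1.66 log units; beyond the scatter). For the compounds shown here, the earlier compounds showed no change on this ring, and their one step, a 2.0-fold lower number from compound 1 to compound 3 (0.31 log units; beyond the scatter), concerned the side chain and was much smaller. Nothing shown here explains the size of the new step.

On these data alone, whether a methyl, chloro or nitrile group at this carbon would match trifluoromethyl remains open. So does whether the same change would have a similar effect with the longer side chain of compound 3.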